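Swapping methyl for fluoro on a chalcone's aryl ring

A few compounds are considered here, and "the series" means these few. Any claim that something is new, unique, unknown or untested is made for them only; others in the source may bear on it.

Measured so far:
- compound 1 `COc1cc(OC)c(OC)cc1/C=C/C(=O)c1ccc(C)cc1`: 81100 nM
- compound 2 `COc1cc(OC)c(-c2cc(=O)c3cc(O)ccc3o2)cc1OC`: > 150000 nM
- compound 3 `COc1cc(OC)c(C(=O)/C=C/c2cc(OC)c(OC)cc2OC)c(OC)c1`: 96500 nM

Of the compounds shown here, three have been tested in a functional assay on SW982 cells (Homo sapiens) for inhibition, read by MTT assay, with a stated time of 72 h; on this read-out lower numbers stand for stronger inhibition and higher numbers for weaker inhibition. Compound 1 gives 81100 nM. Compound 3, which carries extra methoxy groups on the carbonyl side, gives 96500 nM; this number and that of compound 1 lie within the usual scatter of each other, so the two cannot be told apart. For the measured compounds named here, compound 2 reaches only the limit of this assay, > 150000 nM, and so gives no number; it is the one value that sits at the limit of > 150000 nM in this assay, at which 1 of the 3 values shown sits.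

Compound 4 `COc1cc(OC)c(OC)cc1/C=C/C(=O)c1ccc(F)cc1` has not yet been measured. It differs from compound 1 in one place: fluoro in place of methyl on an aromatic carbon. On these data alone, no change of this kind has been measured here, so the size of its effect is unknown. Since a small group is exchanged for another small group, the expected step from compound 1 to compound 4 in this assay is a 1.0-fold higher number from compound 1 to compound 4 (0.02 log units; within the scatter), that is, no change beyond the scatter. Compound 4 is therefore estimated at 85000 nM, between 35000 nM and 200000 nM.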

Compound 4, half-maximal inhibitory concentration: 32500 nM
Compound 4: middle estimate off by 2.6-fold (0.42 log units), on the high side; the whole stated range lies above it.
By their numbers in this assay, from the lowest: compound 4; then compounds 1 and 3 (each within the scatter of the next). At a limit, above all of these: compound 2.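

In this assay, for the compounds shown here, the change gives a 2.5-fold lower number from compound 1 to compound 4 (0.40 log units; beyond the scatter) and is the first single-place change that can be read. It shows that what sits on this aromatic carbon, para to a large group, matters for the read-out. Exchanging just one heavy atom for another, with no ring, hydrogen-bond donor, hydrogen-bond acceptor or net charge entering or leaving, moves the number beyond the scatter, towards stronger inhibition. Nothing measured here explains why the 4-fluorophenyl compound gives the lower number.

Still open, on these data alone, is whether fluoro is special at this place or whether removing methyl is what counts, which a plain hydrogen, chloro, methoxy or an amine there could help to tell. As far as these compounds go, it also remains open whether the same exchange would give a similar step on a different core.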